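The compounds below may be only part of what the source reports. "The series", "measured", "known", "first", "only" and "open" are said of these compounds alone.

In a toxicity assay on NIH3T3 cells (Mus musculus) for cytotoxicity, read by resazurin assay (a lower number here means that less compound is needed, a higher number that more compound is needed for the effect), compound 2, `c1ccc(-c2ccc(Cn3cncc3CNc3ccc(-c4onc5ccccc45)c(-c4ccccc4)c3)cc2)cc1`, gives > 10000 nM. This is a limit of the assay and not a measured number, as the limit of > 10000 nM in this assay, at which 1 of the 2 values shown sits, records. Compound 1, `CNC(=O)c1ccc(NCc2cncn2Cc2ccc(-c3ccccc3)cc2N)cc1-c1ccccc1`, also stops at a limit in this assay, giving > 1000 nM, which the limit of > 1000 nM in this assay, at which 1 of the 2 values shown sits, records. With both values at limits, compound 2 cannot be ranked against compound 1. Compound 3, `CC(C)OC(=O)c1ccc(NCc2cncn2Cc2ccc(-c3ccccc3)cc2)cc1-c1ccccc1`, differs from compound 2 in one place: a group of 6 heavy atoms (4 carbon, 2 oxygen; no ring) in place of a group of 9 heavy atoms (7 carbon, 1 nitrogen, 1 oxygen; one five-membered aromatic ring with 2 hetero atoms, one six-membered aromatic ring of carbon only), on an aromatic carbon. Among the measured compounds shown here, no measured step covers such a change. The step that the limit leaves unreadable from compound 2 to compound 3 is expected to stay within the scatter. For compound 3 the expected value is 15000 nM, ranging from 3000 nM to 60000 nM, most likely again reported only as a limit.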

Compound 3, half-maximal effective concentration: > 10000 nM
Compound 3 gave a limit, no number (the forecaster's own chance of this, stated with the estimate: 80%); the middle value does not contradict the limit.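

In this assay, among the compounds shown here, compound 2 and compound 3 both give limits, not numbers, so no step between them can be read. The compounds shown leave open how much of either is needed for the effect.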